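Sulfonyl aryl swap: fluorophenyl to cyanophenyl

The compounds below may be only part of what the source reports. "The series", "measured", "known", "first", "only" and "open" are said of these compounds alone.

compound 1: `Cc1ccc2ncc(S(=O)(=O)c3ccc(F)cc3)c(N3CCC(C)CC3)c2c1` — 90%
compound 2: `CC1CCN(c2c(S(=O)(=O)c3ccc(F)cc3)cnc3ccc(F)cc23)CC1` — 87%

In an assay on isolated protein for displacement of a labelled ligand from metabotropic glutamate receptor 5 (Homo sapiens), with a stated time of 60 min, tested at 1 uM (a lower number here means less inhibition, a higher number more inhibition at the concentration tested (going by the name of the read-out)), compound 1 gives 90%, the higher of the two numbers, while compound 2 gives 87%; the step of a number 3 percentage points lower from compound 1 to compound 2 (within the scatter) lies within the scatter. Compound 3 `Cc1ccc2ncc(S(=O)(=O)c3cccc(C#N)c3)c(N3CCC(C)CC3)c2c1` differs from compound 1 by 3-cyanophenyl in place of 4-fluorophenyl on a sulfonyl sulfur. Among the compounds with values here, no measured step touches the sulfonyl sulfur; the only step known, a number 3 percentage points lower from compound 1 to compound 2 (within the scatter), concerns another part of the shared core and was flat. The data therefore give no direct guide, so a modest downward shift at most is expected. Compound 3 is expected to give 80%, with a range from 55% to 95%. The expected step is a number 10 percentage points lower from compound 1 to compound 3 (within the scatter).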

Compound 3, a percentage reported as inhibition, at one concentration (the size of the read-out at that concentration, not a potency): 52%
For compound 3 the middle estimate is 28 percentage points above the measured one; the whole stated range lies above it.
By their numbers in this assay, from the lowest: compound 3; then compounds 2 and 1 (each within the scatter of the next).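

The sulfonyl sulfur proves a sensitive place: in this assay, 3-cyanophenyl in place of 4-fluorophenyl gives a number 38 percentage points lower from compound 1 to compound 3 (beyond the scatter) and so brings a large loss of inhibition. Within the data shown here, the one earlier step, at another part of the shared core, gave only a number 3 percentage points lower from compound 1 to compound 2 (within the scatter) and showed nothing of this kind. Nothing measured here explains the drop.

Still open, as far as these compounds go, is whether the nitrile itself counts or where it sits, which 4-cyanophenyl or 3-fluorophenyl would separate. From the compounds shown here alone, how a methoxy group or an amine on that phenyl ring would fare also remains open.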